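A few compounds are considered here, and "the series" means these few. Any claim that something is new, unique, unknown or untested is made for them only; others in the source may bear on it.

Three related compounds have been measured in an ADME assay on HEp-2 cells (Homo sapiens) for cytotoxicity; a lower number here means that less compound is tolerated, a higher number that more compound is tolerated. Compound 1 `CNCc1ccc2c(c1)nc(Cn1c(=O)n(C(C)C)c3ccccc31)n2CCC(C)C` gives 1480 nM, the lowest of the three numbers. Compound 2 `C=C(C)n1c(=O)n(Cc2nc3cc(C(=N)N)ccc3n2CCC(C)C)c2ccccc21` gives 10800 nM and compound 3 `CC(C)CCn1c(Cn2c(=O)n(CC(=O)OC(C)(C)C)c3ccccc32)nc2cc(/C(N)=N\O)ccc21` gives 19800 nM, and the gap from compound 1 to each of them lies beyond the scatter.

Compound 4 `CC(C)CCn1c(Cn2c(=O)n(C(C)C)c3ccccc32)nc2cc(CF)ccc21` has yet to be measured. It keeps the core of compound 1 and alters one group: fluoro in place of methylamino on a saturated chain carbon bound to an aromatic carbon.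

Within the data shown here, no measured pair isolates this change, so any forecast is loose. Compounds 2 and 3 also lack the methylamino group, but they differ from compound 1 elsewhere too. Even so, the expectation leans on compound 2 at 10800 nM and compound 3 at 19800 nM, which both stand higher. A rise beyond the scatter is therefore expected in this assay, with an estimated 8.1-fold higher number from compound 1 to compound 4 (0.91 log units; beyond the scatter). For compound 4 the estimated value is 12000 nM, with an expected range from 3500 nM to 40000 nM.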

Compound 4, half-maximal cytotoxic concentration: 37300 nM
Compound 4: middle estimate off by 3.1-fold (0.49 log units), on the low side, within the range that was stated.
By their numbers in this assay, from the lowest: compound 1; then compounds 2, 3 and 4 (each within the scatter of the next, the first and the last beyond it).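

In this assay, among these compounds, this pair gives the first reading of a single change at this position: on a saturated chain carbon bound to an aromatic carbon, fluoro in place of methylamino brings a large rise (a 25-fold higher number from compound 1 to compound 4 (1.40 log units; beyond the scatter)). The earlier compounds shown here differed from compound 1 in more than one place, whereas here the whole step belongs to the exchange of (methylamino)methyl for fluoromethyl, with the rest of the molecule unchanged. No accompanying measurement bears on why the number moves.

The compounds shown leave open whether the rise follows the loss of methylamino or the arrival of fluoro; a primary amine, a hydroxyl or a plain methyl group on this carbon would speak to that. On these data alone, whether the step keeps its size with other groups elsewhere on the core also remains open.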